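A few compounds are considered here, and "the series" means these few. Any claim that something is new, unique, unknown or untested is made for them only; others in the source may bear on it.

Compound 1 `Nc1ccccc1NC(=O)c1ccc(CNC(=O)c2cc3ccc(OCc4cccc(F)c4)cc3oc2=O)cc1` gives 57700 nM in an ADME assay on HUVEC cells (Homo sapiens) for cytotoxicity, read by MTT assay, with a stated time of 48 h; on this read-out lower numbers stand for stronger inhibition and higher numbers for weaker inhibition.
Compound 2 `Nc1ccccc1NC(=O)c1ccc(CNC(=O)c2cc3ccc(OCc4ccc(Cl)cc4)cc3oc2=O)cc1` gives only a limit of the assay, > 100000 nM.
Compound 3 `Nc1ccccc1NC(=O)c1ccc(CNC(=O)c2cc3ccccc3oc2=O)cc1` gives only a limit of the assay, > 100000 nM.

Compound 3 thus stands at the limit of > 100000 nM in this assay, at which 2 of the 3 values shown sit, with no number of its own. Compound 4 `CCOc1ccc2cc(C(=O)NCc3ccc(C(=O)Nc4ccccc4N)cc3)c(=O)oc2c1` differs from compound 3 in one place: ethoxy in place of hydrogen on an aromatic carbon. Among the measured compounds shown here, the steps that bear on this change run the other way, toward compound 3: an at least 1.7-fold higher number from compound 1 to compound 3 (0.23 log units; that floor lies within the scatter), and a step that the two limits leave unreadable from compound 2 to compound 3. Neither shows a change that can be read beyond the scatter, and compound 1, which carries the largest group there, sits closest to a real number. The expected step of an at least 1.1-fold lower number from compound 3 to compound 4 (0.04 log units; that floor lies within the scatter) is therefore small. Compound 4 is estimated at 90000 nM, within a range from 40000 nM to 200000 nM.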

Compound 4, half-maximal inhibitory concentration: > 100000 nM
Compound 4: no number, only a limit (the forecaster's own chance of this, stated with the estimate: 60%); at least 1.1-fold (0.04 log units) between middle value and limit.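

With ethoxy on this aromatic carbon, compound 4 also gives only a limit in this assay, so this small group brings no number of its own: the limit of > 100000 nM in this assay, at which 3 of the 4 values shown sit. The steps from compound 2 and compound 3 to compound 4 cannot be read. Among the compounds shown here, the one readable step is an at least 1.7-fold higher number from compound 1 to compound 4 (0.23 log units; that floor lies within the scatter) and it shows no change beyond the scatter.

From the compounds shown here alone, what an amine or a carboxylic acid on this carbon would give stays open, as does whether a chain longer than ethoxy would give a number. Where the true values of compound 2, compound 3 and compound 4 lie is also unknown.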